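Aryl ether terminus: tert-butylphenyl exchanged for naphthyl

A few compounds are considered here, and "the series" means these few. Any claim that something is new, unique, unknown or untested is made for them only; others in the source may bear on it.

Compound 1 `NC(=O)c1ccc(OCCCN2CCC(C(c3ccc(F)cc3)c3ccc(F)cc3)CC2)cc1` and compound 2 `CC(C)(C)c1ccc(OCCCN2CCC(C(c3ccc(F)cc3)c3ccc(F)cc3)CC2)cc1` share one core and differ only at the aromatic terminus of the ether chain. In a functional assay (aorta) with Oryctolagus cuniculus as the target (a higher number here means weaker binding, a lower number tighter binding), compound 1 gives 31.6 nM, and compound 2 gives 1 nM. Among the measured compounds shown here, the single step measured so far, a 32-fold lower number from compound 1 to compound 2 (1.50 log units; beyond the scatter), leaves compound 2 with the lowest of the two numbers, compound 1 being its only neighbour and that gap lying beyond the scatter.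

Compound 3 `Fc1ccc(C(c2ccc(F)cc2)C2CCN(CCCOc3cccc4ccccc34)CC2)cc1` is the unmeasured next member: naphthalen-1-yl in place of 4-(tert-butyl)phenyl on an oxygen on a saturated carbon. The change keeps the donor and acceptor counts at zero on both sides and exchanges one six-membered aromatic ring for two; it is not a return toward the carbamoyl of compound 1. For the measured compounds named here, the one measured step bears on this only loosely: it shows that the terminus can move this assay strongly, but it does not say how a second aromatic ring compares with tert-butyl. Going by the values given here, with no closer precedent, a step at or near the scatter is the expectation, a 2.0-fold higher number from compound 2 to compound 3 (0.30 log units; within the scatter). For compound 3 the estimate in this assay is 2 nM, expected within 0.5 nM to 8 nM.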

Compound 3, dissociation constant: 5.01 nM
Compound 3: the middle estimate sits 2.5-fold (0.40 log units) below what was measured; the range from low to high includes it.
By their numbers in this assay, from the lowest: compound 2; then compound 3; then compound 1.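

The exchange at this terminus is not neutral in this assay even though the heavy-atom count, with 10 carbons on each side, and the zero donor and acceptor counts stay the same: a 5.0-fold higher number from compound 2 to compound 3 (0.70 log units; beyond the scatter) is a step beyond the scatter. Carbon count and the absence of donors and acceptors therefore do not fix the number here, and the arrangement of those carbons, as 4-(tert-butyl)phenyl or naphthalen-1-yl, matters. Naphthalen-1-yl also remains clearly better than the carbamoyl terminus, with a 6.3-fold lower number from compound 1 to compound 3 (0.80 log units; beyond the scatter) as the step, which places compound 3 between the other two and shows that a terminus without tert-butyl can still give a low number. No supporting data on the cause of either step are available.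

The change removes tert-butyl and adds a second aromatic ring in one move, so the two contributions cannot be separated with these compounds, and an unsubstituted phenyl or naphthalen-2-yl would bear directly on that. As far as these compounds go, how an amine or a carboxylic acid on the terminal ring would compare with the carbamoyl of compound 1 also stays open.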